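The source may hold more compounds than are shown below. What is called first, only, known or untested is meant among the compounds shown, and "the series" means these compounds.

Working notes on a small set of serine-phosphate esters. Compound 1 `N[C@@H](COP(=O)(O)O[C@@H]1CCCO[C@@H]1COC(=O)CCc1ccccc1OCc1cccc(Oc2ccccc2)c1)C(=O)O` and compound 2 `CCCCCCCC/C=C\CCCCCCCC(=O)O[C@H]1C=CCO[C@@H]1COP(=O)(O)OC[C@H](N)C(=O)O` are both without a reported number. In an assay on HEK293-A cells with putative P2Y purinoceptor 10 (Mus musculus) as the target, with a stated time of 1.5 h (on this read-out lower numbers stand for smaller maximal responses and higher numbers for larger maximal responses), compound 1 gives "not active" (no number reported). In this assay compound 2 likewise gives "not active" (no number reported). Compound 3 `CCCCCCCCCCCOc1ccccc1CCC(=O)OC[C@H]1OCC=C[C@H]1OP(=O)(O)OC[C@H](N)C(=O)O` is the only member with a figure: in this assay compound 3 reaches 0.05, a small maximal response, and it stands alone on the numbers shown, with the two other entries having no single value to compare against.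

Compound 4 `CCCCCCCCCCCOc1ccccc1CCC(=O)OC[C@H]1OCC=C[C@@H]1OP(=O)(O)OC[C@H](N)C(=O)O` is the next member to be run. It differs from compound 3 only in configuration: the two compounds have the same atoms and bonds; at least one stereo element is drawn with a configuration in one of them and without one in the other: 1 of 4 stereo elements differ; a stereocentre at a saturated ring carbon is drawn R in compound 3 and S in compound 4. For the measured compounds named here, no step between measured compounds is available, so the size of a stereochemical inversion in this assay cannot be read from the data. Given that compound 3 sits at 0.05, the expectation is for no step beyond the usual scatter, or at most a small one in either direction. For compound 4 the expected value in this assay is estimated at 0.05, within 0 to 0.2, meaning an expected step of no change at the digits printed from compound 3 to compound 4 (within the scatter).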

Compound 4, intrinsic activity: the largest response reached, as a fraction of the reference agonist's: 0.071
Compound 4: the middle estimate sits 0.021 below what was measured, within the range that was stated.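

In this assay, for the compounds shown here, drawing the stereocentre at a saturated ring carbon as S rather than R gives a number 0.021 higher from compound 3 to compound 4 (within the scatter), the first step that can be read. For this pair, the configuration at this position therefore makes no difference to the maximal response beyond the usual scatter, something the two entries without a number could not show. One caveat applies to this reading of the pair: the fact that one of compounds 3 and 4 is drawn with a defined configuration and the other without, at the place where they differ.

Going by these compounds alone, the single pair does not show whether the same inversion would be equally silent with the other acyl groups on the shared core, such as the unsaturated fatty ester of compound 2. It also leaves open whether an amide in place of the ester, or a phosphonate in place of the phosphate, would lift the response beyond the scatter.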